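Dropping the Methyl of Compound 1: What to Expect

This account rests on a few compounds, and the source may have more. Where it says the series, first, only, none or still open, it means among the compounds named here.

Measured so far:
Compound 1 `Cc1ccc([C@]2(CO)NC[C@@H](O)[C@@H]2O)cc1` gives 0% in an assay on isolated protein for inhibition of alpha-mannosidase (Canavalia ensiformis), tested at 1000 uM; a higher number here means more inhibition at the concentration tested (going by the name of the read-out), a lower number less inhibition.
Compound 2 `Cc1ccc([C@@]2(CO)NC[C@H](O)[C@H]2O)cc1` gives 0% in this assay.

Compound 1 stands level with compound 2 at the digits shown, and its nearest measured neighbour is compound 2. Going by the values given here, the only measured step, no change at the digits printed from compound 1 to compound 2 (within the scatter), shows no change within the scatter; the two compounds are mirror images of one another (the fact that compounds 1 and 2 differ only in the configuration as drawn). Neither compound shows any inhibition at the concentration tested.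

Compound 3 `OC[C@@]1(c2ccccc2)NC[C@@H](O)[C@@H]1O` differs from compound 1 by hydrogen in place of methyl on an aromatic carbon. Among the compounds with values here, no measured step involves a change of this kind, so the measured data give no direction for it. What they do show is that compound 1 sits at the floor of the read-out in this assay, and compound 2 sits there too, so a small change on the aromatic ring is not expected to lift compound 3 clearly above the scatter.

For compound 3 the expected inhibition in this assay is 0%, with a range from -10% to 15%. The expected step of no change at the digits printed from compound 1 to compound 3 (within the scatter) is none beyond the scatter.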

Compound 3, a percentage reported as inhibition, at one concentration (the size of the read-out at that concentration, not a potency): 0%
Compound 3: the middle estimate sits on the measured number at the digits printed; low and high end bracket the measured number.
By their numbers in this assay, from the lowest: compounds 1, 2 and 3 (each within the scatter of the next).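

In this assay, putting hydrogen where the methyl stood on the aromatic ring gives no change at the digits printed from compound 1 to compound 3 (within the scatter), so neither of these two groups at this place, para to a group of 9 heavy atoms, brings inhibition into view at the concentration tested. This is a limited finding: compound 1 gives 0%, so the step could only have shown a gain, and a flat result says nothing about whether the methyl would matter in a compound that does inhibit the enzyme. Nothing measured here explains why the step reads as it does.

Still open, as far as these compounds go, is whether a different group at this same place, such as an amine, a carboxylic acid or a longer chain, would lift the read-out clear of the scatter. Also open is whether the shared core can give any inhibition in this assay at all, since every compound shown so far stays at the bottom of the read-out and the position can only be judged properly once some compound rises from there.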